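Swapping the aryl group on the piperazine nitrogen

This account rests on a few compounds, and the source may have more. Where it says the series, first, only, none or still open, it means among the compounds named here.

Measured compounds:
Compound 1, `Cc1nc(-c2ccccc2)c(C(=O)N2CCN(c3ccc(C(F)(F)F)cc3)CC2)o1`: > 1000 nM
Compound 2, `Cc1nc(-c2ccccc2)c(C(=O)N2CCN(c3ccccc3C(F)(F)F)CC2)o1`: 120 nM

In a functional assay on HL-60 cells (Homo sapiens) for inhibition, read by MTT assay, with a stated time of 72 h (a lower number here means a stronger inhibitor, a higher number a weaker inhibitor), compound 1 reaches only a limit, > 1000 nM, with no number behind it. In this assay compound 2 gives 120 nM, the only number shown, so it stands as the one measured value. The step of an at least 8.3-fold lower number from compound 1 to compound 2 (0.92 log units; beyond the scatter) shows that the group on the amine nitrogen in a ring governs the outcome strongly, though one end of that step is a limit (the limit of > 1000 nM in this assay, at which 1 of the 2 values shown sits).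

Compound 3, `Cc1ccc(C)c(N2CCN(C(=O)c3oc(C)nc3-c3ccccc3)CC2)c1`, is not yet measured. It differs from compound 2 as follows: 2,5-dimethylphenyl in place of 2-(trifluoromethyl)phenyl on an amine nitrogen in a ring. Going by the values given here, only the step from compound 1 to compound 2 bears on this change, and it concerns a different pair of groups, so it gives no direct guide. A modest rise in the number is expected, a 2.5-fold higher number from compound 2 to compound 3 (0.40 log units; beyond the scatter). Compound 3 is estimated at 300 nM, between 80 nM and 1500 nM.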

Compound 3, half-maximal inhibitory concentration: 31.3 nM
For compound 3 the middle estimate is 9.6-fold (0.98 log units) above the measured one, outside the stated range (below it).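

In this assay, 2,5-dimethylphenyl on the amine nitrogen in a ring outperforms both trifluoromethyl-bearing phenyl groups, so this position tolerates an aryl group with no fluorine, and the change gives a 3.8-fold lower number from compound 2 to compound 3 (0.58 log units; beyond the scatter). Against 4-(trifluoromethyl)phenyl, the change gives an at least 31-fold lower number from compound 1 to compound 3 (1.50 log units; beyond the scatter). One end of that step is a limit: the limit of > 1000 nM in this assay, at which 1 of the 3 values shown sits.

The compounds shown leave open whether one methyl group on the phenyl ring would suffice, or whether both are needed. They also leave open how an unsubstituted phenyl or a pyridine ring would fare at this nitrogen.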